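A few compounds are considered here, and "the series" means these few. Any claim that something is new, unique, unknown or untested is made for them only; others in the source may bear on it.

Measured in a functional assay on MCF7 cells (Homo sapiens) for inhibition, read by CCK-8 assay, with a stated time of 72 h; a higher number here means a weaker inhibitor, a lower number a stronger inhibitor:

- compound 1 `O=C(/C=C/c1cccnc1)NCCCc1ccc(S(=O)(=O)Nc2ccccc2)cc1`: 4120 nM
- compound 2 `O=C(/C=C/c1cccnc1)NCCCCCCCc1cccc(S(=O)(=O)Nc2ccccc2)c1`: 42.6 nM
- compound 3 `Cc1ccc(C)c(NS(=O)(=O)c2cccc(CCCCCCNC(=O)/C=C/c3cccnc3)c2)c1`: 0.6 nM

Compound 3 is the strongest inhibitor of the three in this assay. Its number lies beyond the scatter from both others, with compound 2 the nearest and compound 1 the furthest.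

The next compound to be considered is compound 4 `O=C(/C=C/c1cccnc1)NCCCCCCc1cccc(S(=O)(=O)Nc2ccc(C(F)(F)F)cc2)c1`. Compared with compound 3, it has 4-(trifluoromethyl)phenyl in place of 2,5-dimethylphenyl on a sulfonamide nitrogen. For the measured compounds named here, no two measured compounds differ in only one place, so the data show no step for this change alone, and any expectation is loose.

Compound 3 sits at the very low end of the numbers seen so far, at 0.6 nM. Compound 2, which also lacks the 2,5-dimethylphenyl group, gives 42.6 nM, although it differs from compound 3 in other ways too. On that basis, a rise in the number is expected, beyond the scatter, and a moderate loss seems more likely than a fall to the level of compound 1. The expected step is a 13-fold higher number from compound 3 to compound 4 (1.12 log units; beyond the scatter). For compound 4 the estimated value is 8 nM, with an expected range of 1 nM to 60 nM.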

Compound 4, half-maximal inhibitory concentration: 67.8 nM
The estimate for compound 4 lay 8.5-fold (0.93 log units) below the measured number; measured number above the stated range.
By their numbers in this assay, from the lowest: compound 3; then compounds 2 and 4 (each within the scatter of the next); then compound 1.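

In this assay, the exchange of 2,5-dimethylphenyl for 4-(trifluoromethyl)phenyl on the sulfonamide nitrogen gives a 110-fold higher number from compound 3 to compound 4 (2.05 log units; beyond the scatter), the first step among these compounds that isolates a single change, and it shows that this group alone can move the number by a large margin. The six-membered aromatic ring of carbon only, the absence of hydrogen-bond donors and acceptors in the group, and the absence of a net charge are the same on both sides of the change, so a step of this size arises with those features left as they were. No measurement offered here accounts for the rise in the number, so its cause remains unassigned.

This one step changes both the kind of substituent on the ring and where it stands, so it cannot separate the loss of the two methyl groups from the arrival of the trifluoromethyl group. Still open, on these data alone, is where a 4-methylphenyl or a 2,5-bis(trifluoromethyl)phenyl on the same nitrogen would fall relative to compound 3 and compound 4, and whether the size of this step would hold with a different chain length.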